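From acetyl to methylsulfonyl on a shared core

The source may hold more compounds than are shown below. What is called first, only, known or untested is meant among the compounds shown, and "the series" means these compounds.

Measured in a functional assay on KB cells (Homo sapiens) for cytotoxicity; a higher number here means a weaker inhibitor, a lower number a stronger inhibitor:
- compound 1 `CCCOC1=CC(=O)c2ccccc2C1=O`: 49400 nM
- compound 2 `CCCCOC1=CC(=O)c2ccccc2C1=O`: 27000 nM
- compound 3 `CC(=O)OC1=CC(=O)c2ccccc2C1=O`: 38800 nM

At 38800 nM, compound 3 lies within the scatter of the other two: a 1.3-fold lower number from compound 1 to compound 3 (0.10 log units; within the scatter), and a 1.4-fold higher number from compound 2 to compound 3 (0.16 log units; within the scatter). Compound 4 `CS(=O)(=O)OC1=CC(=O)c2ccccc2C1=O` carries a new group, with methylsulfonyl in place of acetyl on an oxygen on an unsaturated carbon. The nearest evidence is the two steps above, which also exchange the group on this oxygen, along with a 1.8-fold lower number from compound 1 to compound 2 (0.26 log units; within the scatter). Among the measured compounds shown here, all three stay within the scatter, but no sulfonyl compound has been measured, so the range stays wide. In this assay, no step beyond the scatter is expected. The expected step is a 1.3-fold lower number from compound 3 to compound 4 (0.11 log units; within the scatter). The estimate for compound 4 is 30000 nM, with an expected range of 10000 nM to 80000 nM.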

Compound 4, half-maximal inhibitory concentration: 7180 nM
Compound 4: middle estimate off by 4.2-fold (0.62 log units), on the high side; the measured number lies below the stated range.
By their numbers in this assay, from the lowest: compound 4; then compounds 2, 3 and 1 (each within the scatter of the next).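

In this assay, the group on this oxygen can matter after all. Propyl, butyl and acetyl stay within the scatter of one another, whereas methylsulfonyl gives three steps beyond it: (a 5.4-fold lower number from compound 3 to compound 4 (0.73 log units; beyond the scatter)), (a 3.8-fold lower number from compound 2 to compound 4 (0.58 log units; beyond the scatter)) and (a 6.9-fold lower number from compound 1 to compound 4 (0.84 log units; beyond the scatter)). Nothing shown explains why this group stands apart.

Still open, as far as these compounds go, is whether this is a feature of sulfonyl groups generally or of methylsulfonyl alone. Phenylsulfonyl or trifluoromethylsulfonyl on the same oxygen would separate those two readings.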